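The compounds below may be only part of what the source reports. "The series", "measured", "known", "first", "only" and "open" are said of these compounds alone.

Measured in an ADME assay (liver) for metabolic stability, with Liver microsome (Canis lupus familiaris) as the target, read by LC-MS, using microsomes, with a stated time of 30 min, tested at 4 uM; on this read-out lower numbers stand for a less stable compound and higher numbers for a more stable compound:
- compound 1 `CCN1CCN(c2nc(C)nc3c2nc(-c2ccccc2Cl)n3CCOC)CC1`: 86%
- compound 2 `COCCn1c(-c2ccccc2Cl)nc2c(N3CCN(C(C)=O)CC3)nc(C)nc21`: 34%

Of these two compounds, compound 2 has the lower number, at 34%. Among the measured compounds shown here, the only measured step, a number 52 percentage points lower from compound 1 to compound 2 (beyond the scatter), is large and beyond the scatter, with acetyl in place of ethyl on an amine nitrogen in a ring.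

Compound 3 `COCCn1c(-c2ccccc2Cl)nc2c(N3CCN4C(=O)CCC4C3)nc(C)nc21` has not yet been measured. Its change is a group of 10 heavy atoms (7 carbon, 2 nitrogen, 1 oxygen; one five-membered non-aromatic ring with 1 hetero atom, one six-membered non-aromatic ring with 2 hetero atoms) in place of a group of 9 heavy atoms (6 carbon, 2 nitrogen, 1 oxygen; one six-membered non-aromatic ring with 2 hetero atoms), on an aromatic carbon: the 4-acetylpiperazin-1-yl group leaves, and a group with an added five-membered non-aromatic ring enters on the same aromatic carbon. For the measured compounds named here, compound 3 still has a carbonyl on that ring nitrogen, so the size of the one measured step is not expected to carry over.

The step expected in this assay is a number 6 percentage points higher from compound 2 to compound 3 (within the scatter), which is no change beyond the scatter. Going by the values given here, with only one measured step, the expected range stays wide. The estimated value for compound 3 is 40%, with an expected range of 20% to 62%.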

Compound 3, percent of the compound remaining: 35%
For compound 3 the middle estimate is 5 percentage points above the measured one; measured number inside the range.
By their numbers in this assay, from the lowest: compounds 2 and 3 (each within the scatter of the next); then compound 1.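

In this assay, putting the group with an added five-membered non-aromatic ring on this aromatic carbon in place of the 4-acetylpiperazin-1-yl group gives a number 1 percentage points higher from compound 2 to compound 3 (within the scatter). Compound 3 also keeps a carbonyl on the ring nitrogen, and a number 51 percentage points lower from compound 1 to compound 3 (beyond the scatter) is large, as is a number 52 percentage points lower from compound 1 to compound 2 (beyond the scatter), so among these three compounds, both with that carbonyl stand well below the one with ethyl, and none goes against this. No measurement here accounts for this pattern.

Still open, on these data alone, is whether the carbonyl itself matters, which a sulfonyl group or a urea on that ring nitrogen would help to test. A two-ring group with a plain amine in place of the carbonyl would show how the added ring behaves without it.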